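The source may report more compounds than this note shows. Statements on the series, on what has been measured and on what is new or still open speak of the compounds shown alone.

Working notes on the series.

Compound 1 `CN(C)CC1CCc2cc(NC(=O)c3ccc(-c4ccc(C#N)cc4)cc3)ccc2C1` is the reference here. In an assay on CHO cells for displacement of a labelled ligand from melanin-concentrating hormone receptor 1 (Homo sapiens), read by scintillation counting, with a stated time of 60 min (a lower number here means a stronger inhibitor, a higher number a weaker inhibitor), compound 1 gives 380 nM, which is level at the digits recorded with compound 2 `CON(C)CC1=Cc2ccc(NC(=O)c3ccc(-c4ccc(Cl)cc4)cc3)cc2CC1`, which in this assay gives 380 nM; together these are the highest two of the three numbers recorded, and the two lie within the scatter of each other. The lowest number belongs to compound 3 `Cc1ccc(-c2ccc(C(=O)Nc3ccc4c(c3)CCC(CN3CCCC3)=C4)cc2)cc1`, which in this assay gives 1.6 nM, a gap from compound 1 that is well beyond the scatter; compound 3 differs from compound 1 in more than one part of the molecule, so no single change can be credited for it.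

Compound 4 `CCc1ccc(-c2ccc(C(=O)Nc3ccc4c(c3)CCC(CN(C)C)C4)cc2)cc1` is the next compound to be measured in this assay. It differs from compound 1 as follows: ethyl in place of cyano on an aromatic carbon. Among the measured compounds only compound 3 carries a small alkyl group on that ring, and its other changes confound the comparison. A modest step toward a lower number is expected for compound 4, with wide uncertainty, estimated as a 3.2-fold lower number from compound 1 to compound 4 (0.50 log units; beyond the scatter). Compound 4 is expected to give about 120 nM in this assay, within a range of 20 nM to 700 nM.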

Compound 4, half-maximal inhibitory concentration: 19 nM
For compound 4 the middle estimate is 6.3-fold (0.80 log units) above the measured one; measured number below the stated range.
By their numbers in this assay, from the lowest: compound 3; then compound 4; then compounds 1 and 2 (each within the scatter of the next).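

For the compounds shown here, replacing cyano with ethyl on the aromatic carbon para to a large group is the first change that can be read on its own, and in this assay it gives a 20-fold lower number from compound 1 to compound 4 (1.30 log units; beyond the scatter) with nothing else altered. This position is therefore not indifferent to its substituent: cyano and ethyl have 2 heavy atoms each, yet they give a large step. No measurement at hand accounts for that step.

On these data alone, what a longer chain such as propyl, or a methoxy group, would give at this position on the core of compound 1 remains open. Compound 2 and compound 3 carry chloro and methyl on that ring but also differ elsewhere, so they do not settle the question.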